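Shifting the aryl substituent on the shared core

The source may hold more compounds than are shown below. What is called first, only, known or untested is meant among the compounds shown, and "the series" means these compounds.

Compound 1 `COc1cc(-n2cnc3ccc(-c4ccc([N+](=O)[O-])cc4)cc32)cc(OC)c1OC`: 79 nM
Compound 2 `COc1cc(-n2cnc3ccc(-c4ccc(C(F)(F)F)cc4)cc32)cc(OC)c1OC`: 890 nM
Compound 3 `COc1cccc(-c2ccc3ncn(-c4cc(OC)c(OC)c(OC)c4)c3c2)c1`: 3310 nM

These three compounds share one core and differ only in the aryl group attached to it. In a functional assay on SGC-7901 cells (Homo sapiens) for antiproliferative activity, read by MTT assay, with a stated time of 72 h (on this read-out higher numbers stand for weaker inhibition and lower numbers for stronger inhibition), compound 3 gives the highest number of the three, so it is the weakest inhibitor here. Compound 4 `COc1cc(-n2cnc3ccc(-c4cccc(C)c4C)cc32)cc(OC)c1OC` keeps the core and introduces a (2,3-dimethylphenyl in place of 3-methoxyphenyl on an aromatic carbon).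

Among the measured compounds shown here, two measured steps bear on this change, as both alter the same aryl group: a 42-fold higher number from compound 1 to compound 3 (1.62 log units; beyond the scatter) and a 3.7-fold higher number from compound 2 to compound 3 (0.57 log units; beyond the scatter). Both show that swapping this aryl group can move the number a great deal, and that 3-methoxyphenyl gave the weakest result so far. Nothing measured shows a 2,3-dimethylphenyl, so the direction is uncertain; the nearest comparison is the modest 3.7-fold higher number from compound 2 to compound 3 (0.57 log units; beyond the scatter). A modest step downward is expected, a 1.5-fold lower number from compound 3 to compound 4 (0.18 log units; within the scatter), with a wide range allowed. Compound 4 is estimated at 2200 nM, between 600 nM and 8000 nM.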

Compound 4, half-maximal inhibitory concentration: 3040 nM
Beside the measured number, compound 4's estimate is 1.4-fold (0.14 log units) below it, within the range that was stated.
By their numbers in this assay, from the lowest: compound 1; then compound 2; then compounds 4 and 3 (each within the scatter of the next).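

In this assay, putting 2,3-dimethylphenyl where 3-methoxyphenyl stood gives a 1.1-fold lower number from compound 3 to compound 4 (0.04 log units; within the scatter) and so no real change, even though one group holds an oxygen and the other only carbon. The other two steps, a 3.4-fold higher number from compound 2 to compound 4 (0.53 log units; beyond the scatter) and a 38-fold higher number from compound 1 to compound 4 (1.59 log units; beyond the scatter) here, show that compound 4 shares the high end of the series with compound 3, so a second aryl group has now landed level with the 3-methoxyphenyl result. No measurement at hand explains why these aryl groups fall where they do.

The compounds shown leave open whether the low number of compound 1 belongs to the nitro group alone. A phenyl ring carrying an amine, a nitrile or a carboxylic acid at this position could help settle that.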